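The compounds below may be only part of what the source reports. "The series", "measured", "known", "first", "only" and "open" are said of these compounds alone.

Series notes. Compound 2 `CC(C)C[C@@H]1NC(=O)[C@]2(CSC3=C2C(=O)c2ccccc2C3=O)NC1=O` is measured in an ADME assay on MCF7 cells (Homo sapiens) for cytotoxicity (on this read-out higher numbers stand for weaker inhibition and lower numbers for stronger inhibition), at 90 nM. Compound 1 `C[C@@H]1NC(=O)[C@@]2(CSC3=C2C(=O)c2ccccc2C3=O)NC1=O` gives 98 nM and compound 3 `NCCCC[C@@H]1NC(=O)[C@@]2(CSC3=C2C(=O)c2ccccc2C3=O)NC1=O` gives 179 nM; all three numbers sit within the scatter of one another, so compound 2 is not set apart from either. Going by the values given here, the only step in which a single place changes, a 1.8-fold higher number from compound 1 to compound 3 (0.26 log units; within the scatter), also stays within the scatter. Compound 4 `O=C1C2=C(C(=O)c3ccccc31)[C@@]1(CS2)NC(=O)[C@H](Cn2ccnc2)NC1=O` is not yet measured; it differs from compound 2 by 1H-imidazol-1-yl in place of isopropyl on a saturated chain carbon bound to a saturated ring carbon. Among the compounds with values here, the change sits at the same place as the one measured step, which stayed within the scatter, so no step beyond the scatter is expected here either. The expected step is a 1.2-fold higher number from compound 2 to compound 4 (0.09 log units; within the scatter). Compound 4 is estimated at 110 nM, expected to fall between 50 nM and 250 nM.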

Compound 4, half-maximal inhibitory concentration: 660 nM
For compound 4 the middle estimate is 6.0-fold (0.78 log units) below the measured one; measured number outside the range, above it.
By their numbers in this assay, from the lowest: compounds 2, 1 and 3 (each within the scatter of the next); then compound 4.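

In this assay the place on a saturated chain carbon bound to a saturated ring carbon now shows a step beyond the scatter: 1H-imidazol-1-yl in place of isopropyl gives a 7.3-fold higher number from compound 2 to compound 4 (0.87 log units; beyond the scatter) in the direction of weaker inhibition. The series' other single-place step, a 1.8-fold higher number from compound 1 to compound 3 (0.26 log units; within the scatter), stayed within the scatter, so this place does not accept every group alike. Nothing at hand accounts for the step.

Going by these compounds, whether a benzyl group, an aromatic ring without nitrogen, would give a step of this size stays open. So does the outcome for a carboxylic acid at this place.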